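The compounds below may be only part of what the source reports. "The series", "measured", "known", "first", "only" and "open" are said of these compounds alone.

The series shares a core in which an oxime ether carboxylic acid hangs from a saturated carbon that also carries a cycloalkyl ring and a phenyl ether. Compound 1 `C/C(=N\OC(c1ccc(OCc2ccc3ccccc3n2)cc1)C1CCCCCC1)C(=O)O` gives 13 nM in a functional assay for inhibition of Polyunsaturated fatty acid 5-lipoxygenase (Homo sapiens); a lower number here means a stronger inhibitor, a higher number a weaker inhibitor. Compound 2 `C/C(=N\OC(c1ccc(OCc2ccc3cc(F)ccc3n2)cc1)C1CCCCC1)C(=O)O` gives 20 nM in this assay. Of the two numbers, compound 2 has the higher one, but its gap to compound 1 lies within the scatter, so the two cannot be ordered. Compound 3 `C/C(=N\OC(c1ccc(OCc2nc(-c3ccccc3)cs2)cc1)C1CCCCC1)C(=O)O` has not yet been measured. It differs from compound 2 in one place: 4-phenyl-1,3-thiazol-2-yl in place of 6-fluoroquinolin-2-yl on a saturated chain carbon bound to an oxygen on an aromatic ring. Among the measured compounds shown here, no step between measured compounds covers this kind of exchange, and the two measured numbers sit close together, so there is little to lean on. A step toward a weaker inhibitor is expected, of a size near the edge of the scatter, as a 2.0-fold higher number from compound 2 to compound 3 (0.30 log units; within the scatter). Compound 3 is therefore expected to give about 40 nM in this assay, within a range from 12 nM to 150 nM.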

Compound 3, half-maximal inhibitory concentration: 20 nM
For compound 3 the middle estimate is 2.0-fold (0.30 log units) above the measured one; the measured number falls inside the stated range.
By their numbers in this assay, from the lowest: compounds 1, 2 and 3 (each within the scatter of the next).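

In this assay, 4-phenyl-1,3-thiazol-2-yl in place of 6-fluoroquinolin-2-yl on a saturated chain carbon bound to an oxygen on an aromatic ring brings no change at the digits printed from compound 2 to compound 3 (within the scatter). Among the compounds shown here, this is the first exchange that can be read at this place, and it shows that a group with one five-membered aromatic ring with 2 hetero atoms and one six-membered aromatic ring of carbon only reads the same as one with two six-membered aromatic rings, at the same count of 11 heavy atoms. Nothing available explains why the two groups read alike.

From the compounds shown here alone, what a bare 1,3-thiazol-2-yl or a 4-methyl-1,3-thiazol-2-yl would give at this place remains open. So does the effect of a fluorine or an amine on the phenyl of the 4-phenyl-1,3-thiazol-2-yl group.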